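Swapping chloro for methoxy on the fused ring of compound 2

The source may report more compounds than this note shows. Statements on the series, on what has been measured and on what is new or still open speak of the compounds shown alone.

Compound 1 `COc1ccc2nc(NC(=O)c3cn(-c4ccccc4)nc3-c3ccccc3)sc2c1`: > 50000 nM
Compound 2 `O=C(Nc1nc2ccc(Cl)cc2s1)c1cn(-c2ccccc2)nc1-c1ccc(F)cc1`: 3320 nM

Going by the values given here, in a functional assay on HT-29 cells (Homo sapiens) for cytotoxicity, read by MTT assay, with a stated time of 72 h (on this read-out higher numbers stand for weaker inhibition and lower numbers for stronger inhibition), compound 2 gives 3320 nM, the only plain number measured here. Compound 1 gives > 50000 nM, a limit of the assay rather than a number. Compound 3 `COc1ccc2nc(NC(=O)c3cn(-c4ccccc4)nc3-c3ccc(F)cc3)sc2c1` keeps the fluorophenyl of compound 2 and makes one change: methoxy in place of chloro on an aromatic carbon. Compound 1 also carries a methoxy at that place and sits at the limit, so a loss of potency beyond the scatter is expected. Compound 3 is expected near 20000 nM, between 5000 nM and 60000 nM, the step of a 6.0-fold higher number from compound 2 to compound 3 (0.78 log units; beyond the scatter) being toward weaker inhibition.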

Compound 3, half-maximal inhibitory concentration: 33200 nM
Compound 3: middle estimate off by 1.7-fold (0.22 log units), on the low side, and the stated range covers the measured number.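

With the fluorophenyl held the same in both compounds, the effect of methoxy in place of chloro can now be read as a number rather than a limit. In this assay the swap gives a 10-fold higher number from compound 2 to compound 3 (1.00 log units; beyond the scatter), so this aromatic carbon of the fused ring is sensitive to the change. The fluoro in place of hydrogen gives an at least 1.5-fold lower number from compound 1 to compound 3 (0.17 log units; that floor lies within the scatter), which shows no clear effect of that change, and its reading stops at a limit: the limit of > 50000 nM in this assay, at which 1 of the 3 values shown sits.

As far as these compounds go, whether an amine or a longer chain such as ethoxy on this carbon would give stronger or weaker inhibition than chloro remains open. So does whether chloro itself gives stronger inhibition than a plain hydrogen there.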